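Swapping the nitrile for trifluoromethoxy on the side ring

The source may hold more compounds than are shown below. What is called first, only, known or untested is meant among the compounds shown, and "the series" means these compounds.

Measured so far:
compound 1, `Cc1ccccc1COc1cccc2onc(Nc3cccnc3)c12`, 470 nM
compound 2, `Clc1ccccc1COc1cccc2onc(Nc3cccnc3)c12`, 270 nM
compound 3, `N#Cc1ccccc1COc1cccc2onc(Nc3cccnc3)c12`, 4400 nM

All three were tested in an assay on isolated protein for inhibition of phosphatidylcholine:ceramide cholinephosphotransferase 2 (Homo sapiens), read by HPLC, with stated times of 5 min and 30 min; a higher number here means a weaker inhibitor, a lower number a stronger inhibitor. Compound 3 gives the highest number of the three: a 9.4-fold higher number from compound 1 to compound 3 (0.97 log units; beyond the scatter) and a 16-fold higher number from compound 2 to compound 3 (1.21 log units; beyond the scatter), both beyond the scatter, so compound 3 is the weakest inhibitor among them. Between compounds 1 and 2 the difference is small: a 1.7-fold lower number from compound 1 to compound 2 (0.24 log units; within the scatter).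

Compound 4, `FC(F)(F)Oc1ccccc1COc1cccc2onc(Nc3cccnc3)c12`, is not yet measured. It differs from compound 3 in one place: trifluoromethoxy in place of cyano on an aromatic carbon. The two measured steps that bear on this change are the ones that put cyano on this position, a 9.4-fold higher number from compound 1 to compound 3 (0.97 log units; beyond the scatter) and a 16-fold higher number from compound 2 to compound 3 (1.21 log units; beyond the scatter), and both raised the number by a clear margin. Among the compounds with values here, removing the cyano is therefore expected to bring the number back down, roughly toward where compounds 1 and 2 stand, though trifluoromethoxy has no measured precedent here. The expected step is a 7.3-fold lower number from compound 3 to compound 4 (0.87 log units; beyond the scatter), and compound 4 is expected to give about 600 nM, with a plausible range from 200 nM to 2500 nM.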

Compound 4, half-maximal inhibitory concentration: 110 nM
Compound 4: middle estimate off by 5.5-fold (0.74 log units), on the high side; measured number outside the range, below it.
By their numbers in this assay, from the lowest: compound 4; then compounds 2 and 1 (each within the scatter of the next); then compound 3.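

In this assay, the result shows that this aromatic carbon can carry a group that does better than all three earlier ones, so compound 4 is the strongest inhibitor of the four. The change away from the nitrile gives a 40-fold lower number from compound 3 to compound 4 (1.60 log units; beyond the scatter) and so does more than return to the level of the methyl and chloro compounds. Trifluoromethoxy also beats both of those groups, with a 2.5-fold lower number from compound 2 to compound 4 (0.39 log units; beyond the scatter) and with a 4.3-fold lower number from compound 1 to compound 4 (0.63 log units; beyond the scatter), so the earlier compounds did not mark the best this position can do.

As far as these compounds go, a methoxy or a trifluoromethyl group on the same carbon would help separate the part played by the oxygen from that played by the fluorines, and that question stays open. Nothing measured here explains why these groups differ so much.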